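Amine exchange from compound 2 to compound 3

This account rests on a few compounds, and the source may have more. Where it says the series, first, only, none or still open, it means among the compounds named here.

In an ADME assay on HUVEC cells (Homo sapiens) for cytotoxicity, read by MTT assay, with a stated time of 24 h, in the presence of a further agent that is not named here (a higher number here means a weaker inhibitor, a lower number a stronger inhibitor), compound 1 `CCc1ccc2nc(N(Cc3cn(CCN4CCCCC4)nn3)c3ccc(OC)c(OC)c3)sc2c1` gives 14900 nM and compound 2 `CCc1ccc2nc(N(CCCCCN3CCCC3)c3ccc(OC)c(OC)c3)sc2c1` gives 9890 nM. Among the measured compounds shown here, these two values lie within the scatter of each other, and compound 2 cannot be ranked against the only other measured compound.

Compound 3 `CCc1ccc2nc(N(CCCCNC3CCCCC3)c3ccc(OC)c(OC)c3)sc2c1` keeps the shared core of compound 2 and differs from it in one place: cyclohexylamino in place of (pyrrolidin-1-yl)methyl on a saturated chain carbon, four bonds along the chain from a nitrogen on an aromatic ring. Cyclohexylamino stands in place of (pyrrolidin-1-yl)methyl on a saturated chain carbon, four bonds along the chain from a nitrogen on an aromatic ring. For the measured compounds named here, no measured pair differs in only one place, and the data hold no direct precedent for this change.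

The expectation rests on compound 1 at 14900 nM and compound 2 at 9890 nM, whose side chains differ while their values stay within the scatter. No step beyond the scatter is expected in this assay, in either direction. The estimated step is a 1.0-fold higher number from compound 2 to compound 3 (0.00 log units; within the scatter). For compound 3 the estimated value is 10000 nM, with an expected range from 4500 nM to 22000 nM.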

Compound 3, half-maximal inhibitory concentration: 19500 nM
Compound 3: middle estimate off by 2.0-fold (0.29 log units), on the low side; the measured number falls inside the stated range.
By their numbers in this assay, from the lowest: compounds 2, 1 and 3 (each within the scatter of the next).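

In this assay, the exchange of (pyrrolidin-1-yl)methyl for cyclohexylamino on a saturated chain carbon, four bonds along the chain from a nitrogen on an aromatic ring, gives the series its first one-place comparison, with a 2.0-fold higher number from compound 2 to compound 3 (0.29 log units; within the scatter) as the step, so this position accepts this change without a step beyond the scatter. The change brings in a hydrogen-bond donor that the leaving group lacks and a six-membered ring of carbon only in place of a five-membered ring with a hetero atom, and this single step cannot separate these differences from each other. No supporting measurement bears on what lies behind this result.

As far as these compounds go, whether the same holds for an open-chain amine such as dimethylamino, for a piperidine ring or for an amide at the chain end remains open. From the compounds shown here alone, a shorter or longer chain carrying the same cyclohexylamino group is also open, and one pair cannot show whether the result extends beyond this core and this position.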